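The source may report more compounds than this note shows. Statements on the series, on what has been measured and on what is new or still open speak of the compounds shown alone.

Compound 1 `CN(C)c1ccc(C(=O)NC(CCCCCC(=O)NO)C(=O)NCc2ccccc2)cc1`: 60 nM
Compound 2 `O=C(CCCCC[C@H](NC(=O)c1ccc(Br)cc1)C(=O)Nc1ccc(-c2ccccc2)cc1)NO`: 168 nM
Compound 3 `CN(C)c1ccc(C(=O)N[C@@H](CCCCCC(=O)NO)C(=O)Nc2cccc3cccnc23)cc1`: 73 nM

In a functional assay on SK-MEL-28 cells (Homo sapiens) for antiproliferative activity (a lower number here means a stronger inhibitor, a higher number a weaker inhibitor), compound 1 gives 60 nM, compound 2 gives 168 nM and compound 3 gives 73 nM. On these three numbers compound 3 sits with the second highest value; its number and that of compound 1 lie within the scatter of each other, so nothing separates them, while compound 2 has a higher number than compound 3 and that gap lies beyond the scatter.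

Compound 4 `O=C(/C=C/c1ccccc1)N[C@@H](CCCCCC(=O)NO)C(=O)Nc1cccc2cccnc12` has not yet been measured in this assay. It differs from compound 3 in one place: 2-phenylethenyl in place of 4-(dimethylamino)phenyl on a carbonyl carbon, so the change is 2-phenylethenyl in place of 4-(dimethylamino)phenyl on a carbonyl carbon whose other neighbours are an amide-type nitrogen. For the measured compounds named here, no measured pair shows this change on its own, so the expected step rests on compound 3 alone and on the spread of the three numbers.

The step from compound 3 to compound 4 is expected to be small, a 1.4-fold higher number from compound 3 to compound 4 (0.14 log units; within the scatter), probably not beyond the scatter, with a slight lean toward a higher number. For compound 4 the estimate in this assay is 100 nM, with a range from 40 nM to 250 nM.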

Compound 4, half-maximal inhibitory concentration: 37 nM
The estimate for compound 4 lay 2.7-fold (0.43 log units) above the measured number; measured number outside the range, below it.
By their numbers in this assay, from the lowest: compounds 4, 1 and 3 (each within the scatter of the next); then compound 2.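

On the carbonyl carbon whose other neighbours are an amide-type nitrogen, 2-phenylethenyl can take the place of 4-(dimethylamino)phenyl in this assay with no change that can be told from the scatter: a 2.0-fold lower number from compound 3 to compound 4 (0.30 log units; within the scatter). For this pair, then, the dimethylamino nitrogen and its hydrogen-bond acceptor are not needed to keep the number in this range, and a double bond outside the aromatic ring is accepted at this place. No measurement here explains the result.

As far as these compounds go, it remains open whether a plain phenyl without the double bond, or a group with no aromatic ring such as a short alkyl chain, would serve equally well here. From the compounds shown here alone, it is also open whether a carboxylic acid or a primary amine on the phenyl ring would be accepted at this place.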